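Swapping the Aryl Substituent in a Hydroxamic Acid Series

A few compounds are considered here, and "the series" means these few. Any claim that something is new, unique, unknown or untested is made for them only; others in the source may bear on it.

Three compounds have been measured in a functional assay on MDA-MB-231 cells (Homo sapiens) for inhibition, read by sulforhodamine B assay; a higher number here means a weaker inhibitor of growth, a lower number a stronger inhibitor of growth:

Compound 1, `O=C(CCC1=CCN(CCCc2ccc(Br)cc2)C1=O)NO`, gives 2210 nM.
Compound 2, `O=C(CCC1=CCN(CCCc2ccc(Cl)cc2)C1=O)NO`, gives 2210 nM.
Compound 3, `CCOc1ccc(CCCN2CC=C(CCC(=O)NO)C2=O)cc1`, gives 2210 nM.

None of the three stands apart from the others: no change at the digits printed from compound 1 to compound 2 (within the scatter), no change at the digits printed from compound 2 to compound 3 (within the scatter), and no change at the digits printed from compound 1 to compound 3 (within the scatter). The next compound, compound 4 `Cc1ccccc1CCCN1CC=C(CCC(=O)NO)C1=O`, differs from compound 2 by 2-methylphenyl in place of 4-chlorophenyl on a saturated chain carbon, three bonds along the chain from an amide-type nitrogen in a ring. Each step measured so far also exchanges the group on an aromatic carbon, and none moved the read-out, so no step beyond the scatter is expected in this assay. Compound 4 is therefore expected to give 2210 nM, within 1100 nM to 4400 nM. The expected step is no change at the digits printed from compound 2 to compound 4 (within the scatter), flat within the scatter.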

Compound 4, concentration for 50% growth inhibition: 2210 nM
The estimate for compound 4 equals the measured number at the digits printed, and the stated range covers the measured number.
By their numbers in this assay, from the lowest: compounds 1, 2, 3 and 4 (each within the scatter of the next).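

Exchanging the whole aryl group, rather than only the group on an aromatic carbon, also left the read-out flat, with no change at the digits printed from compound 2 to compound 4 (within the scatter) and no change at the digits printed from compound 1 to compound 4 (within the scatter). On this saturated chain carbon, 2-methylphenyl, which holds carbon only, therefore reads the same as 4-chlorophenyl and 4-bromophenyl. Nothing measured here explains why the read-out stays flat. From the compounds shown here alone, whether an amine or a carboxylic acid on the phenyl ring, or a longer chain leading to it, would shift the value in this assay remains open. So does the effect of any change to the shared core.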